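A few compounds are considered here, and "the series" means these few. Any claim that something is new, unique, unknown or untested is made for them only; others in the source may bear on it.

In a physicochemical assay for lipophilicity, measured as octanol-water partition (a lower number here means a more polar compound, a higher number a more lipophilic compound), three compounds have been measured so far:

Compound 1 `CC(=O)Oc1ccccc1-c1nnc(CNc2c(C)n(C)n(-c3ccccc3)c2=O)o1`: 1.98
Compound 2 `Cc1cccc(-c2nnc(CNc3c(C)n(C)n(-c4ccccc4)c3=O)o2)c1`: 2.39
Compound 3 `Cc1ccccc1-c1nnc(CNc2c(C)n(C)n(-c3ccccc3)c2=O)o1`: 2.38

Compound 3 stands second highest of these three numbers. Its nearest neighbour is compound 2, which differs only by a number 0.01 log units lower from compound 2 to compound 3 (within the scatter), a gap within the scatter of the method. The furthest is compound 1, where the difference is a number 0.40 log units higher from compound 1 to compound 3 (beyond the scatter).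

Compound 4 `COc1ccc(-c2nnc(CNc3c(C)n(C)n(-c4ccccc4)c3=O)o2)cc1` has not yet been measured in this assay. It differs from compound 3 in one place: 4-methoxyphenyl in place of 2-methylphenyl on an aromatic carbon.

Going by the values given here, two measured steps bear on this change. Moving a methyl from one position of the phenyl to another gave a number 0.01 log units lower from compound 2 to compound 3 (within the scatter), so the position of a substituent on that ring mattered little. Exchanging the acetoxy for a methyl gave a number 0.40 log units higher from compound 1 to compound 3 (beyond the scatter), and the parallel exchange to compound 2 gave a number 0.41 log units higher from compound 1 to compound 2 (beyond the scatter). Among the compounds with values here, compound 1, the only measured compound whose phenyl carries a group with an oxygen, has the lowest number. Within the data shown here, no measured step puts a methoxy in place of a methyl, so the expectation rests on that single comparison. A modest downward step of a number 0.43 log units lower from compound 3 to compound 4 (beyond the scatter) is therefore expected for compound 4. The estimate for compound 4 is 1.95, with a range from 1.6 to 2.3.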

Compound 4, partition coefficient: 2.07
Estimate against measurement, compound 4: 0.12 log units below; the range from low to high includes it.
By their numbers in this assay, from the lowest: compounds 1 and 4 (each within the scatter of the next); then compounds 3 and 2 (each within the scatter of the next).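

In this assay, the change to 4-methoxyphenyl gives a number 0.31 log units lower from compound 3 to compound 4 (beyond the scatter), and likewise a number 0.32 log units lower from compound 2 to compound 4 (beyond the scatter), so a second group carrying an oxygen now sits apart from both methylphenyl compounds, with no compound among these four going against that split. Against the 2-acetoxyphenyl group the result is a number 0.09 log units higher from compound 1 to compound 4 (within the scatter), which means these two oxygen-bearing groups cannot be told apart in this measurement. No measurement shown gives a reason for this shift.

The compounds shown hold no pair with methyl and methoxy at the same place on the phenyl. The step from the methylphenyl compounds to compound 4 therefore changes both the group and its place, and the two changes cannot be separated here. Also open, from the compounds shown here alone, is how the number responds to an amine, a carboxylic acid or a longer chain on that phenyl.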